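Urea replacement in histamine H3 ligands: benzylamine variant

The source may report more compounds than this note shows. Statements on the series, on what has been measured and on what is new or still open speak of the compounds shown alone.

Three ureas built on the shared core of compound 1 `CC1CCCN1C1CCN(c2ccc(NC(=O)Nc3cc(Cl)cc(Cl)c3)cc2)C1` have been measured in an assay on CHO cells for displacement of a labelled ligand from histamine receptor H3 (Macaca mulatta), read by scintillation counting, with a stated time of 1 h; on this read-out lower numbers stand for stronger inhibition and higher numbers for weaker inhibition. Compound 1 gives 19.1 nM, compound 2 `CC1CCCN1C1CCN(c2ccc(NC(=O)N3CCCCC3)cc2)C1` gives 6 nM, and compound 3 `CC(=O)N(C)C1CCN(C(=O)Nc2ccc(N3CCC(N4CCCC4C)C3)cc2)C1` gives 35.5 nM. Compound 3 stands at the highest number of the three: a 5.9-fold higher number from compound 2 to compound 3 (0.77 log units; beyond the scatter), while a 1.9-fold higher number from compound 1 to compound 3 (0.27 log units; within the scatter). The step to compound 2 runs the other way, a 3.2-fold lower number from compound 1 to compound 2 (0.50 log units; beyond the scatter).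

Compound 4 `CC1CCCN1C1CCN(c2ccc(NC(=O)NCc3cc(Cl)cc(Cl)c3)cc2)C1` carries (3,5-dichlorobenzyl)amino in place of 3-(acetyl(methyl)amino)pyrrolidin-1-yl on a carbonyl carbon. Within the data shown here, the step that bears most on it is the one between compound 1 and compound 3, since compound 1 also carries a 3,5-dichlorophenyl group on the urea, and that step was within the scatter. Compound 4 is therefore expected to land near compound 1 and near compound 3. For compound 4 the expected step is a 1.8-fold lower number from compound 3 to compound 4 (0.25 log units; within the scatter). The estimate for compound 4 in this assay is 20 nM, with a range from 7 nM to 60 nM.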

Compound 4, inhibition constant: 7.1 nM
For compound 4 the middle estimate is 2.8-fold (0.45 log units) above the measured one; the range from low to high includes it.
By their numbers in this assay, from the lowest: compounds 2 and 4 (each within the scatter of the next); then compounds 1 and 3 (each within the scatter of the next).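

In this assay, 3,5-dichlorobenzyl in place of 3,5-dichlorophenyl on the amide-type nitrogen gives a change beyond the scatter (a 2.7-fold lower number from compound 1 to compound 4 (0.43 log units; beyond the scatter)), so at this position a change confined to the linkage of the dichlorinated ring moves the number. Until now only piperidin-1-yl stood at the low end on this carbonyl carbon, but (3,5-dichlorobenzyl)amino matches it (a 1.2-fold higher number from compound 2 to compound 4 (0.07 log units; within the scatter)) and stands clear of 3-(acetyl(methyl)amino)pyrrolidin-1-yl (a 5.0-fold lower number from compound 3 to compound 4 (0.70 log units; beyond the scatter)), so an aromatic group and a saturated ring can both reach this level here. No measurement is available that explains why the benzyl compound sits at this level.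

The compounds shown leave open whether the two chlorines are needed, or whether a plain benzylamine or a longer chain such as phenethylamine would hold the number of compound 4. They also leave open what a methyl group on the benzylamine nitrogen would do.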